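Lengthening the Chain Toward the Hydroxamate in Compound 4

This account rests on a few compounds, and the source may have more. Where it says the series, first, only, none or still open, it means among the compounds named here.

Compound 3 `O=C(CCCCSc1nc(O)cc(CCc2ccccc2)n1)NO` gives 46 nM in an assay on isolated protein for inhibition of histone deacetylase HD1B (Zea mays); a lower number here means a stronger inhibitor, a higher number a weaker inhibitor. Among the three measured compounds it holds the second highest number: compound 2 `O=C(CCCSc1nc(O)cc(-c2ccccc2)n1)NO` gives 31 nM, a value within the scatter of that of compound 3, whereas compound 1 `O=C(CCCSc1nc(O)cc(CCc2ccccc2)n1)NO` gives 170 nM, a gap beyond the scatter. Compound 4 `O=C(CCCCCCSc1nc(O)cc(CCc2ccccc2)n1)NO` carries 2-(hydroxycarbamoyl)ethyl in place of hydroxycarbamoyl on a saturated chain carbon, four bonds along the chain from a sulfur. Within the data shown here, the one measured step that bears on this change is a 3.7-fold lower number from compound 1 to compound 3 (0.57 log units; beyond the scatter), a modest gain on lengthening the same chain. A further lengthening is expected to bring, in this assay, a step of a 1.2-fold lower number from compound 3 to compound 4 (0.06 log units; within the scatter), at most a small further gain or none beyond the scatter. Compound 4 is therefore expected to show 40 nM, with a range from 12 nM to 150 nM.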

Compound 4, half-maximal inhibitory concentration: 62 nM
For compound 4 the middle estimate is 1.6-fold (0.19 log units) below the measured one; the measured number falls inside the stated range.
By their numbers in this assay, from the lowest: compounds 2, 3 and 4 (each within the scatter of the next); then compound 1.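

In this assay the gain on lengthening does not continue at this position: there is a 1.3-fold higher number from compound 3 to compound 4 (0.13 log units; within the scatter) on going to 2-(hydroxycarbamoyl)ethyl, so the two chain lengths cannot be told apart. Against the shortest chain, 3-(hydroxycarbamoyl)propyl still gives a 2.7-fold lower number from compound 1 to compound 4 (0.44 log units; beyond the scatter) and so keeps a modest advantage. Nothing at hand explains this levelling. The compounds shown leave open whether a longer chain would keep this level or lose it. They also leave open whether a carboxylic acid could stand in place of hydroxycarbamoyl at any of these chain lengths.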